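Moving a chlorine around the amide-bearing phenyl ring

The compounds below may be only part of what the source reports. "The series", "measured", "known", "first", "only" and "open" are said of these compounds alone.

Compound 1 `Cn1cc(-c2cnc(N)c(Oc3ccc(C(=O)Nc4ccccc4Cl)cc3)n2)cn1` — 66900 nM
Compound 2 `Cn1cc(-c2cnc(N)c(Oc3ccc(C(=O)Nc4ccc(Cl)cc4)cc3)n2)cn1` — 11900 nM

In a functional assay on HepG2 cells (Homo sapiens) for inhibition, read by MTT assay, with a stated time of 72 h (a lower number here means a stronger inhibitor, a higher number a weaker inhibitor), compound 1 gives 66900 nM and compound 2 gives 11900 nM. For the measured compounds named here, compound 2 thus holds the lowest number of the two measured; the only step between them, a 5.6-fold lower number from compound 1 to compound 2 (0.75 log units; beyond the scatter), is beyond the scatter. Compound 3 `Cn1cc(-c2cnc(N)c(Oc3ccc(C(=O)Nc4cccc(Cl)c4)cc3)n2)cn1` differs from compound 2 by 3-chlorophenyl in place of 4-chlorophenyl on an amide-type nitrogen. The step from compound 1 to compound 2 is the one that bears on this change: it shows that where the chlorine sits on the ring matters, and the new placement lies structurally between those two. A number somewhere between the two measured values is therefore expected, though not far from compound 2. For compound 3 the estimate is 20000 nM, within 7000 nM to 60000 nM, which amounts to an expected step of a 1.7-fold higher number from compound 2 to compound 3 (0.23 log units; within the scatter).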

Compound 3, half-maximal inhibitory concentration: 21200 nM
Estimate against measurement, compound 3: 1.1-fold (0.03 log units) below, and the stated range covers the measured number.
By their numbers in this assay, from the lowest: compounds 2 and 3 (each within the scatter of the next); then compound 1.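

With the 3-chlorophenyl group on the amide-type nitrogen, the result cannot be told apart from that of the 4-chlorophenyl group, with a 1.8-fold higher number from compound 2 to compound 3 (0.25 log units; within the scatter). Only the 2-chlorophenyl group stands apart, and the second comparison, a 3.2-fold lower number from compound 1 to compound 3 (0.50 log units; beyond the scatter), confirms this. No accompanying data offer an explanation for this pattern. As far as these compounds go, it remains open whether the same pattern would hold if the chlorine were replaced by a methoxy group or an amine. Also open, from the compounds shown here alone, is whether a second chlorine on this phenyl ring would change the number.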